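The compounds below may be only part of what the source reports. "The series", "measured", "known", "first", "only" and "open" are said of these compounds alone.

Measured so far:
- compound 1, `CN1CCN(CC(=O)OC2CC3(N(C)C)CC(c4ccccc4)C2C(c2ccccc2)C3)CC1`, 39900 nM
- compound 2, `CN1CCN(CC(=O)N2CCC3(N4CCCC4)CC(c4ccccc4)C2C(c2ccccc2)C3)CC1`, 69100 nM
- compound 3, `CN1CCN(CCC(=O)NC2CC3(N(C)C)CC(c4ccccc4)C2C(c2ccccc2)C3)CC1`, 95000 nM

All three numbers come from an ADME assay on L6 cells (Rattus norvegicus) for cytotoxicity, read by resazurin assay, with a stated time of 72 h (on this read-out lower numbers stand for stronger inhibition and higher numbers for weaker inhibition), a test of how strongly each compound harms a rat muscle cell line. Compound 2 sits with its number between those of compound 1 and compound 3, and both gaps are within the usual scatter of this assay, so the three compounds cannot be told apart on these numbers.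

Compound 4, `CN1CCN(CC(=O)N2CCC3(N(C)C)CC(c4ccccc4)C2C(c2ccccc2)C3)CC1`, has not yet been measured. It differs from compound 2 in one place: dimethylamino in place of pyrrolidin-1-yl on a saturated ring carbon. Because compound 1, which carries the same dimethylamino group on the same shared core, gives 39900 nM, a number not separable from that of compound 2, no step beyond the scatter is expected from compound 2 to compound 4; the expected step is a 1.3-fold lower number from compound 2 to compound 4 (0.10 log units; within the scatter).

Compound 4 is therefore estimated to give 55000 nM in this assay, most likely between 25000 nM and 120000 nM.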

Compound 4, half-maximal inhibitory concentration: 195000 nM
For compound 4 the middle estimate is 3.5-fold (0.55 log units) below the measured one; the whole stated range lies below it.
By their numbers in this assay, from the lowest: compounds 1, 2 and 3 (each within the scatter of the next, the first and the last beyond it); then compound 4.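

In this assay the exchange of pyrrolidin-1-yl for dimethylamino on this saturated ring carbon gives a modest step beyond the scatter (a 2.8-fold higher number from compound 2 to compound 4 (0.45 log units; beyond the scatter)), so on this read-out the open-chain group goes with weaker harm to the cells than the ring does. This is the first pair shown that differs in one place only, and it shows that the choice of amine at this position can move the number on this shared core. No accompanying measurement offers a reason for the step, so its cause remains unknown.

With a single pair, no trend can be drawn for this position. From the compounds shown here alone, it remains open where other amines would fall on this core, such as piperidin-1-yl, morpholin-4-yl or an unsubstituted amino group.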